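The source may report more compounds than this note shows. Statements on the series, on what has been measured and on what is new or still open speak of the compounds shown alone.

Compound 3 `CCn1c(C(=O)N(C)CC(=O)O)ccc1C(CC)(CC)c1ccc(OCC(O)C(C)(C)C)c(C)c1` gives the highest number of the three measured in an assay on HL-60 cells for agonist activity at vitamin D3 receptor (Homo sapiens), read by microscopy, with a stated time of 96 h (a higher number here means that more compound is needed for the effect, a lower number that less compound is needed), at 740 nM. Compound 1 `CCOC(=O)CN(C)C(=O)c1ccc(C(CC)(CC)c2ccc(OCC(O)C(C)(C)C)c(C)c2)n1CC` gives 210 nM in this assay, and compound 2 `CCn1c(C(=O)NCCCN(C)C)ccc1C(CC)(CC)c1ccc(OCC(O)C(C)(C)C)c(C)c1` gives 37 nM. The step in hand runs from compound 3 to compound 4 `CCn1c(C(=O)OCc2ccccn2)ccc1C(CC)(CC)c1ccc(OCC(O)C(C)(C)C)c(C)c1` through ((pyridin-2-yl)methoxy in place of (carboxymethyl)(methyl)amino on a carbonyl carbon). Among the measured compounds shown here, two measured steps bear on it: the free acid of compound 3 came from compound 1 by the step of a 3.5-fold higher number from compound 1 to compound 3 (0.55 log units; beyond the scatter), and the contrasting step a 20-fold higher number from compound 2 to compound 3 (1.30 log units; beyond the scatter) shows how far the carboxymethyl group sets the number back. Compound 4 carries neither, so a step of roughly the reverse size of the acid step is expected, a 4.9-fold lower number from compound 3 to compound 4 (0.69 log units; beyond the scatter). Compound 4 is therefore estimated at 150 nM, with a range from 40 nM to 600 nM.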

Compound 4, half-maximal effective concentration: > 50000 nM
Compound 4: a limit, no number (the forecaster's own chance of this, stated with the estimate: 5%); at least 330-fold (2.52 log units) between middle value and limit.
By their numbers in this assay, from the lowest: compound 2; then compound 1; then compound 3. At a limit, above all of these: compound 4.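

In this assay compound 4 stands at a limit and not a number: the limit of > 50000 nM in this assay, at which 1 of the 4 values shown sits. Among the compounds shown here, all three amino groups on this carbonyl carbon give measured numbers, whereas (pyridin-2-yl)methoxy is the only group here that does not, with an at least 67-fold higher number from compound 3 to compound 4 (1.82 log units; beyond the scatter), an at least 230-fold higher number from compound 1 to compound 4 (2.37 log units; beyond the scatter) and an at least 1300-fold higher number from compound 2 to compound 4 (3.13 log units; beyond the scatter). The place therefore tolerates a change of amino group with a measurable result, but this replacement takes the series out of the measured range.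

Open, going by these compounds, is whether the limit follows the oxygen on the carbonyl carbon or the pyridin-2-yl ring. A (pyridin-2-yl)methylamino group or a benzyloxy group in the same place would separate the two.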